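From 4-nitrophenyl to 3-chlorophenyl on a shared core

The source may hold more compounds than are shown below. What is called first, only, known or untested is meant among the compounds shown, and "the series" means these compounds.

Three compounds sharing one core were tested in a functional assay on MIA PaCa-2 cells (Homo sapiens) for inhibition, read by MTT assay, with a stated time of 48 h, tested at 10 uM (a lower number here means less inhibition of growth, a higher number more inhibition of growth at the concentration tested), and all gave small numbers. Compound 1 (`Cc1cc(=O)c2c(O)c(CN3CCC(c4ccccc4)CC3)c(O)c([C@H]3CCN(C)C[C@H]3O)c2o1`) reached 16% in this test, and compound 2 (`Cc1cc(=O)c2c(O)c(CN(C(C)C)C(C)C)c(O)c([C@H]3CCN(C)C[C@H]3O)c2o1`) reached 11% there. Compound 3 (`Cc1oc2c([C@H]3CCN(C)C[C@H]3O)c(O)cc(O)c2c(=O)c1C(O)c1ccc([N+](=O)[O-])cc1`) gave 2% in this assay which lies within the scatter of compound 2 and beyond the scatter under compound 1.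

Compound 4 (`Cc1oc2c([C@H]3CCN(C)C[C@H]3O)c(O)cc(O)c2c(=O)c1C(O)c1cccc(Cl)c1`) has not yet been measured. It carries 3-chlorophenyl in place of 4-nitrophenyl on a saturated chain carbon bound to an aromatic carbon and an oxygen on a saturated carbon. Within the data shown here, no measured pair shows this exchange, so its size cannot be read from the data. The expectation rests on compound 3 at 2% and on compound 1 at 16% as the nearest guides. A slight upward move and nothing beyond the scatter is expected in this assay with the estimated step of a number 4 percentage points higher from compound 3 to compound 4 (within the scatter) as its size. For compound 4 the estimate is 6% with an expected range from 0% to 15% in this read-out.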

Compound 4, percent growth inhibition at one concentration: 2%
The estimate for compound 4 lay 4 percentage points above the measured number; low and high end bracket the measured number.
By their numbers in this assay, from the lowest: compounds 3, 4, 2 and 1 (each within the scatter of the next, the first and the last beyond it).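

Putting 3-chlorophenyl in place of 4-nitrophenyl on a saturated chain carbon bound to an aromatic carbon and an oxygen on a saturated carbon gave no change at the digits printed from compound 3 to compound 4 (within the scatter) in this assay. Among these compounds, this is the first exchange at this position that can be read, and it shows that this read-out does not depend on keeping 4-nitrophenyl there, even though the hydrogen-bond acceptors counted for that group are absent from 3-chlorophenyl. No measurement shown bears on the reason for this result.

Steps from these two compounds to compound 1 or compound 2 cannot be read, as those compounds differ in more than one place. Going by these compounds, it remains open whether an aminophenyl group, a carboxyphenyl group or a longer alkyl chain at this position would change the number.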